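Notes on an aryl exchange on the shared core

This account rests on a few compounds, and the source may have more. Where it says the series, first, only, none or still open, it means among the compounds named here.

For the measured compounds named here, in a functional assay on MGC-803 cells (Homo sapiens) for cytotoxicity, read by MTT assay, with a stated time of 72 h (a lower number here means a stronger inhibitor, a higher number a weaker inhibitor), compound 1 (`CC(C)=C1C(=O)N(c2ccc(Cl)cc2)N(c2ccc(Cl)cc2)C1=O`) gives 39000 nM and compound 2 (`COc1cc(C=C2C(=O)N(c3ccc(Cl)cc3)N(c3ccc(Cl)cc3)C2=O)ccc1O`) gives 21800 nM as the two numbers available so far. Compound 2 therefore stands within the scatter of compound 1, and the two cannot be told apart on this read-out.

The next compound is compound 3 (`O=C1C(=Cc2ccc(Cl)cc2Cl)C(=O)N(c2ccc(Cl)cc2)N1c1ccc(Cl)cc1`), which differs from compound 2 by 2,4-dichlorophenyl in place of 4-hydroxy-3-methoxyphenyl on a double-bonded chain carbon bound to a double-bonded ring carbon in one place: 2,4-dichlorophenyl in place of 4-hydroxy-3-methoxyphenyl on a double-bonded chain carbon bound to a double-bonded ring carbon.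

Going by the values given here, no measured pair differs in one place only, so this exchange has no direct precedent. Among the compounds with values here, the only guide is that compound 1 at 39000 nM and compound 2 at 21800 nM fall within the scatter of each other while carrying different groups on the shared core. The expected change is a 1.1-fold lower number from compound 2 to compound 3 (0.04 log units; within the scatter) and so no step beyond the scatter is expected in this assay for this exchange. For compound 3 the estimated value is 20000 nM with an expected range from 8000 nM to 50000 nM on this read-out.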

Compound 3, half-maximal inhibitory concentration: > 128000 nM
Compound 3 ended at the assay's limit; the forecaster's own chance of this, stated with the estimate: 10%; middle value at least 6.4-fold (0.80 log units) from the limit.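

On a double-bonded chain carbon bound to a double-bonded ring carbon, 2,4-dichlorophenyl in place of 4-hydroxy-3-methoxyphenyl gives an at least 5.8-fold higher number from compound 2 to compound 3 (0.76 log units; beyond the scatter) in this assay. For the compounds shown here, this is the only step that can be read and it lies beyond the scatter, so the aryl group at this position is not indifferent to the read-out, something the earlier compounds, with no pair differing in one place, could not show. For compound 3 the entry > 128000 nM is a limit of the assay and not a number, so the full size of the step stays unknown: the limit of > 128000 nM in this assay, at which 1 of the 3 values shown sits.

The exchange removes the hydroxy and methoxy groups and brings in the chlorines in a single move, and the compounds shown do not separate the share of each in the step. Also open, going by these compounds, is where a 4-hydroxyphenyl, a 3-methoxyphenyl, a 4-chlorophenyl or a phenyl carrying an amine or a carboxylic acid would fall at this position relative to compound 2 and compound 3.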